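A Methylimidazole in Place of a Methylthiazole

This account rests on a few compounds, and the source may have more. Where it says the series, first, only, none or still open, it means among the compounds named here.

Of the compounds shown here, three on a shared core have been measured in a functional assay on CHO-K1 cells for antagonist activity at adenosine receptor A1 (Homo sapiens), read by a beta-galactosidase reporter and cAMP accumulation, with stated times of 15 min and 6 h; on this read-out lower numbers stand for stronger inhibition and higher numbers for weaker inhibition. Compound 1 `CC(C)c1ccc(-c2nc(N)c3cc(Cc4ccccc4)sc3n2)o1` gives 283 nM in this assay, compound 2 `Nc1nc(-c2ccc(C(F)F)o2)nc2sc(Cc3ccccc3)cc12` gives 3000 nM, and compound 3 `Cc1csc(-c2nc(N)c3cc(Cc4ccccc4)sc3n2)n1` gives 1490 nM. Among these three numbers compound 3 stands second highest; compound 2 is nearest to it and compound 1 furthest. The nearer step is a 2.0-fold lower number from compound 2 to compound 3 (0.30 log units; within the scatter), whereas the further one is a 5.3-fold higher number from compound 1 to compound 3 (0.72 log units; beyond the scatter). The remaining step, an 11-fold higher number from compound 1 to compound 2 (1.03 log units; beyond the scatter), shows that the group on the aromatic carbon between the two ring nitrogen atoms can move the number by a large amount.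

Compound 4 `Cn1cnc(-c2nc(N)c3cc(Cc4ccccc4)sc3n2)c1` has not yet been measured. It differs from compound 3 in one place: 1-methyl-1H-imidazol-4-yl in place of 4-methyl-1,3-thiazol-2-yl on an aromatic carbon. Within the data shown here, no measured step exchanges one five-membered heteroaryl for another at this position. Because a 2.0-fold lower number from compound 2 to compound 3 (0.30 log units; within the scatter) lies within the scatter while a 5.3-fold higher number from compound 1 to compound 3 (0.72 log units; beyond the scatter) is modest, the exchange of a five-membered ring of equal size is expected to give at most a modest step. A step of modest size toward a higher number is expected for compound 4, namely a 1.7-fold higher number from compound 3 to compound 4 (0.22 log units; within the scatter). Compound 4 is estimated at 2500 nM in this assay, with a range from 700 nM to 9000 nM.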

Compound 4, inhibition constant: 2330 nM
Beside the measured number, compound 4's estimate is 1.1-fold (0.03 log units) above it, within the range that was stated.
By their numbers in this assay, from the lowest: compound 1; then compounds 3, 4 and 2 (each within the scatter of the next).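

In this assay, among these compounds, the exchange of 4-methyl-1,3-thiazol-2-yl for 1-methyl-1H-imidazol-4-yl is the first measured swap between two five-membered aromatic rings that each carry a small methyl group and no furan oxygen, and it gives (a 1.6-fold higher number from compound 3 to compound 4 (0.19 log units; within the scatter)), so these two rings are not told apart at this position on the aromatic carbon between two ring nitrogen atoms. Among the compounds shown here, compound 4 also stays level with the difluoromethyl furan (a 1.3-fold lower number from compound 2 to compound 4 (0.11 log units; within the scatter)) but not with the isopropyl furan (an 8.2-fold higher number from compound 1 to compound 4 (0.92 log units; beyond the scatter)), which leaves compound 1 as the only one of the four compounds whose number stands apart, with compounds 2, 3 and 4 forming a group within the scatter of each other. No measurement shown here accounts for this result.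

From the compounds shown here alone, it remains open whether the isopropyl group would bring the same low number on the imidazole or thiazole ring as on the furan, or whether the pairing with the furan ring matters. Going by these compounds, the effect of a six-membered ring such as pyridine or phenyl at this position, or of a tert-butyl group on the furan, also stays open.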